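Swapping isopropyl on the amide of compound 2

The source may hold more compounds than are shown below. What is called first, only, known or untested is meant among the compounds shown, and "the series" means these compounds.

Compound 1 `CN(C)Cc1ccc(-c2cnc(N)c(C(=O)NC3CCCCC3)n2)cc1`: 190000 nM
Compound 2 `CC(C)NC(=O)c1nc(-c2ccc(CN(C)C)cc2)cnc1N`: > 1000000 nM (a limit)

In a physicochemical assay for solubility, at pH 6.8 (a lower number here means a less soluble compound, a higher number a more soluble compound), compound 2 has only a limit, > 1000000 nM. This is the limit of > 1000000 nM in this assay, at which 1 of the 2 values shown sits. Compound 3 `CN(C)Cc1ccc(-c2cnc(N)c(C(=O)NCC(O)C(F)(F)F)n2)cc1` carries 3,3,3-trifluoro-2-hydroxypropyl in place of isopropyl on an amide-type nitrogen. Among the measured compounds shown here, one measured step bears on this change at that nitrogen: an at least 5.2-fold higher number from compound 1 to compound 2 (0.72 log units; beyond the scatter), which lies beyond the scatter. Taking that step as the only guide to size, a modest move towards a lower number is expected, an at least 1.6-fold lower number from compound 2 to compound 3 (0.22 log units; that floor lies within the scatter), although a second limit remains possible. Compound 3 is estimated at 600000 nM, with an expected range of 200000 nM to 1000000 nM.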

Compound 3, solubility: 880000 nM
Compound 3: the middle estimate sits 1.5-fold (0.17 log units) below what was measured; the range from low to high includes it.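

In this assay, 3,3,3-trifluoro-2-hydroxypropyl in place of cyclohexyl gives a 4.6-fold higher number from compound 1 to compound 3 (0.67 log units; beyond the scatter), so a second chain without a ring on the amide-type nitrogen, and one with more heavy atoms than isopropyl, also stands above the cyclohexyl amide. Against isopropyl the change gives an at least 1.1-fold lower number from compound 2 to compound 3 (0.05 log units; that floor lies within the scatter), so the two chains cannot be firmly ordered. Compound 2 is a limit, not a number: the limit of > 1000000 nM in this assay, at which 1 of the 3 values shown sits.

Left open is how a 2-hydroxypropyl chain without fluorine would read in this assay. Also open, from the compounds shown here alone, is what a smaller ring such as cyclopropyl, or a chain ending in an amine or a carboxylic acid, would give at this nitrogen.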